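Plain Phenyl Replacing a Dichlorinated Ring on the Carbonyl

A few compounds are considered here, and "the series" means these few. Any claim that something is new, unique, unknown or untested is made for them only; others in the source may bear on it.

Measured compounds:
Compound 1, `COc1ccc(C(=O)/C=C/c2cccc(OCc3ccccc3)c2)cc1`: in a functional assay on PANC-1 cells (Homo sapiens) for cytotoxicity, read by MTT assay, with a stated time of 68 h (a lower number here means a stronger inhibitor, a higher number a weaker inhibitor), compound 1 gives 44300 nM.
Compound 2, `O=C(/C=C/c1cccc(OCc2ccccc2)c1)c1cccc(Br)c1`: compound 2 gives 6400 nM.
Compound 3, `O=C(/C=C/c1cccc(OCc2ccccc2)c1)c1ccc(Cl)cc1Cl`: compound 3 gives 27200 nM.

Compound 3 stands second highest of the three numbers. Compound 1 is its nearest neighbour, a 1.6-fold lower number from compound 1 to compound 3 (0.21 log units; within the scatter), a step within the scatter. Compound 2 is the furthest, a 4.3-fold higher number from compound 2 to compound 3 (0.63 log units; beyond the scatter), a step beyond it.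

Compound 4, `O=C(/C=C/c1cccc(OCc2ccccc2)c1)c1ccccc1`, differs from compound 3 in one place: phenyl in place of 2,4-dichlorophenyl on a carbonyl carbon.

All three measured steps change the ring on the carbonyl carbon, so all bear on this one. They were a 6.9-fold lower number from compound 1 to compound 2 (0.84 log units; beyond the scatter), a 1.6-fold lower number from compound 1 to compound 3 (0.21 log units; within the scatter) and a 4.3-fold higher number from compound 2 to compound 3 (0.63 log units; beyond the scatter). Swapping that ring has therefore moved the number modestly at most, in either direction. Another such swap is expected to give a step of similar size or smaller, with no clear direction, so compound 4 is estimated at a 1.4-fold lower number from compound 3 to compound 4 (0.13 log units; within the scatter). Compound 4 is expected to give about 20000 nM, in a range from 6000 nM to 60000 nM.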

Compound 4, half-maximal inhibitory concentration: 23500 nM
For compound 4 the middle estimate is 1.2-fold (0.07 log units) below the measured one; low and high end bracket the measured number.
By their numbers in this assay, from the lowest: compound 2; then compounds 4, 3 and 1 (each within the scatter of the next).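

Compound 4 has a plain phenyl on the carbonyl carbon, which gives the shared core a baseline with no added group on that ring. In this assay phenyl in place of 2,4-dichlorophenyl gives a step within the scatter (a 1.2-fold lower number from compound 3 to compound 4 (0.06 log units; within the scatter)), and hydrogen in place of methoxy does too (a 1.9-fold lower number from compound 1 to compound 4 (0.28 log units; within the scatter)), so neither of those substituted rings can be told apart from plain phenyl. Hydrogen in place of bromo is different (a 3.7-fold higher number from compound 2 to compound 4 (0.56 log units; beyond the scatter)), which leaves the bromo group of compound 2 as the only one of the three that stands apart from the baseline, with the lower number.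

No measurement here accounts for this result. From the compounds shown here alone, it also stays open whether an amine or a carboxylic acid on that ring would stand apart from plain phenyl as bromo does.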